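Hepatocyte clearance notes: step from compound 3 to compound 4

The source may hold more compounds than are shown below. What is called first, only, known or untested is meant among the compounds shown, and "the series" means these compounds.

Measured so far in an ADME assay on cells (Hepatocyte, Rattus norvegicus) for metabolic stability; a lower number here means slower removal, a higher number faster removal of the compound:
compound 1 `Cc1ccc2[nH]c(C(=O)N[C@H]3CCN(S(=O)(=O)N4CCOCC4)C[C@@H]3C(=O)NCCN(C)C)cc2c1`: 6 uL/min
compound 2 `Cc1ccc2[nH]c(C(=O)N[C@H]3CN(S(=O)(=O)c4ccccc4)C[C@@H]3C(=O)NC[C@H]3CCCN3)cc2c1`: 10 uL/min
compound 3 `Cc1ccc2[nH]c(C(=O)N[C@H]3CN(S(=O)(=O)c4ccccc4)C[C@@H]3C(=O)NC[C@H]3CCCN3C)cc2c1`: 21 uL/min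

Compound 3 gives the highest number of the three in this assay; compound 2 sits nearest, compound 1 furthest, both beyond the scatter. Compound 4 `Cc1ccc2[nH]c(C(=O)N[C@H]3CN(S(=O)(=O)c4ccccc4)C[C@@H]3C(=O)N[C@@H]3CCCNC3)cc2c1` is not yet measured. The change from compound 3 is piperidin-3-yl in place of (1-methylpyrrolidin-2-yl)methyl on an amide-type nitrogen. Within the data shown here, the only measured step that bears on it is a 2.1-fold higher number from compound 2 to compound 3 (0.32 log units; beyond the scatter), which concerns the same amine nitrogen; compound 4 undoes that methylation, but the ring and its attachment also change, so the step is only partly comparable. A modest decrease in this assay is expected, of roughly the size seen between compound 2 and compound 3. Compound 4 is expected to give 11 uL/min, within 6 uL/min to 22 uL/min. The expected step is therefore a 1.9-fold lower number from compound 3 to compound 4 (0.28 log units; within the scatter).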

Compound 4, intrinsic clearance in a liver preparation (reported as CLH), per the amount of preparation that the assay uses: 9 uL/min
Estimate against measurement, compound 4: 1.2-fold (0.09 log units) above, and the stated range covers the measured number.
By their numbers in this assay, from the lowest: compounds 1, 4 and 2 (each within the scatter of the next); then compound 3.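

In this assay, piperidin-3-yl in place of (1-methylpyrrolidin-2-yl)methyl on the amide-type nitrogen gives a 2.3-fold lower number from compound 3 to compound 4 (0.37 log units; beyond the scatter). In place of (pyrrolidin-2-yl)methyl, it gives a 1.1-fold lower number from compound 2 to compound 4 (0.05 log units; within the scatter), so with no methyl on the ring nitrogen, this change of ring and attachment stays within the scatter. No supporting data bear on the cause of these steps.

Open, as far as these compounds go, is whether a methyl on the ring nitrogen of piperidin-3-yl would give a step like a 2.1-fold higher number from compound 2 to compound 3 (0.32 log units; beyond the scatter). Also open, from the compounds shown here alone, is how a carboxylic acid or a piperidin-4-yl group would read on this amide-type nitrogen.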